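From Trifluoroethoxy to Isobutylsulfanyl: A Cytotoxicity Limit Under Test

The source may report more compounds than this note shows. Statements on the series, on what has been measured and on what is new or still open speak of the compounds shown alone.

In an ADME assay on Akata cells (Homo sapiens) for cytotoxicity, with a stated time of 7 days (a lower number here means that less compound is tolerated, a higher number that more compound is tolerated), compound 2 `Nc1nc(OCC(F)(F)F)c2ncn(/C=C3/CC3(CO)CO)c2n1` gives > 20000 nM, which is a limit and not a number. Compound 1 `CNc1nc(N)nc2c1ncn2/C=C1/CC1(CO)CO` gives > 24000 nM, also a limit. Among the measured compounds shown here, the only measured step so far is a step that the two limits leave unreadable from compound 1 to compound 2. It replaces one group on an aromatic carbon of the shared core, but it has no readable size and shows no direction.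

Compound 3 `CC(C)CSc1nc(N)nc2c1ncn2/C=C1/CC1(CO)CO` changes that same carbon again, with isobutylsulfanyl in place of 2,2,2-trifluoroethoxy on an aromatic carbon. This new group has not yet been tested in this assay, so the estimate rests on thin evidence. With no readable step to build on, no change beyond the scatter is expected, and the expected move is an at least 1.1-fold lower number from compound 2 to compound 3 (0.04 log units; that floor lies within the scatter). Compound 3 is estimated at 18000 nM, with an expected range from 7000 nM to 40000 nM.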

Compound 3, half-maximal cytotoxic concentration: > 20000 nM
Compound 3 ended at the assay's limit; the forecaster's own chance of this, stated with the estimate: 60%; middle value at least 1.1-fold (0.04 log units) away from the limit.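

Among the compounds shown here, compound 1, compound 2 and compound 3 all give limits of the assay and not numbers, so no step among them can be read. Still open, on these data alone, is where each compound's true half-maximal cytotoxic concentration lies, and whether methylamino, 2,2,2-trifluoroethoxy or isobutylsulfanyl changes it at all.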